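Ethoxy to isopropoxy on the shared core

A few compounds are considered here, and "the series" means these few. Any claim that something is new, unique, unknown or untested is made for them only; others in the source may bear on it.

Compound 3 `CCOc1cc(C)c(C(=O)N=C(N)N)cc1S(C)(=O)=O` gives 19 nM in a functional assay for inhibition of sodium/hydrogen exchanger (Oryctolagus cuniculus); a higher number here means a weaker inhibitor, a lower number a stronger inhibitor. Compound 1 `Cc1cc(Br)c(S(C)(=O)=O)cc1C(=O)N=C(N)N` gives 12 nM and compound 2 `Cc1cc(Sc2cccc(Cl)c2)c(S(C)(=O)=O)cc1C(=O)N=C(N)N` gives 37 nM. Compound 3 is separated from compound 1 by a 1.6-fold higher number from compound 1 to compound 3 (0.20 log units; within the scatter) and from compound 2 by a 1.9-fold lower number from compound 2 to compound 3 (0.29 log units; within the scatter), so the three numbers are not distinguishable from one another; only a 3.1-fold higher number from compound 1 to compound 2 (0.49 log units; beyond the scatter) exceeds the scatter.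

Compound 4 `Cc1cc(OC(C)C)c(S(C)(=O)=O)cc1C(=O)N=C(N)N` differs from compound 3 by methyl in place of hydrogen on a saturated chain carbon bound to an oxygen on an aromatic ring and a saturated chain carbon, ethoxy to isopropoxy. Going by the values given here, no measured step changes the ether chain itself; the steps that bear on it are those at the same aromatic carbon, where bromo, ethoxy and (3-chlorophenyl)sulfanyl span a 3.1-fold higher number from compound 1 to compound 2 (0.49 log units; beyond the scatter) at most and a 1.6-fold higher number from compound 1 to compound 3 (0.20 log units; within the scatter) for the closest analogue. Extending the chain by one carbon is therefore expected to produce no shift beyond the scatter, estimated as a 1.3-fold higher number from compound 3 to compound 4 (0.12 log units; within the scatter). Compound 4 is expected to give about 25 nM in this assay, with a range of 10 nM to 60 nM.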

Compound 4, half-maximal inhibitory concentration: 19 nM
Compound 4: middle estimate off by 1.3-fold (0.12 log units), on the high side; the measured number falls inside the stated range.
By their numbers in this assay, from the lowest: compounds 1, 3, 4 and 2 (each within the scatter of the next, the first and the last beyond it).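

At this aromatic carbon, the first step inside the ether chain itself, ethoxy to isopropoxy, gives no change at the digits printed from compound 3 to compound 4 (within the scatter) in this assay. Isopropoxy also stays within the scatter of the other two groups at this carbon, with a 1.6-fold higher number from compound 1 to compound 4 (0.20 log units; within the scatter) and a 1.9-fold lower number from compound 2 to compound 4 (0.29 log units; within the scatter), so the only step beyond the scatter in the set remains a 3.1-fold higher number from compound 1 to compound 2 (0.49 log units; beyond the scatter). No available data explain why the added methyl leaves the number unchanged.

Going by these compounds, it remains open whether a longer chain such as butoxy, or a branched ether such as tert-butoxy, would also stay within the scatter of compound 3. An amine or a carboxylic acid at the same aromatic carbon would show whether this flat response extends beyond the ether, bromo and sulfanyl groups.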